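Trimming a diaryl piperidine side chain to a bare benzyl group

The compounds below may be only part of what the source reports. "The series", "measured", "known", "first", "only" and "open" are said of these compounds alone.

Measured so far:
Compound 1 `COc1cc(C(C)=O)ccc1OCCCN1CCC(C(c2ccc(F)cc2)c2ccc(F)c(F)c2)CC1`: 1.26 nM
Compound 2 `COc1cc(C(C)O)ccc1OCCCN1CCC(C(c2ccc(F)cc2)c2ccc(F)cc2)CC1`: 10 nM

Both compounds were tested in a functional assay (aorta) with Oryctolagus cuniculus as the target; on this read-out higher numbers stand for weaker binding and lower numbers for tighter binding. Compound 2 holds the higher of the two numbers, which here means the weaker binding; compound 1 sits well below it, and the gap between them lies beyond the usual scatter of repeat measurements. Compound 1 and compound 2 differ in more than one place, so no single structural reason for that gap can be read from the two values alone.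

Compound 3 `Fc1ccc(C(c2ccc(F)cc2)C2CCN(CCCCc3ccccc3)CC2)cc1` has not yet been measured. Compared with compound 2, the change is benzyl in place of 4-(1-hydroxyethyl)-2-methoxyphenoxy on a saturated chain carbon, three bonds along the chain from an amine nitrogen in a ring. A large oxygen-bearing portion of the side chain is removed and replaced by a much smaller, hydrocarbon-only group, leaving the shared core untouched.

For the measured compounds named here, with no directly comparable step among the measured compounds, the expectation rests on the size of the portion lost. The step from compound 2 to compound 3 is expected to be a 3.0-fold higher number from compound 2 to compound 3 (0.48 log units; beyond the scatter), a weakening beyond the scatter. For compound 3 in this assay, the estimate is 30 nM, within a range from 6 nM to 150 nM.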

Compound 3, dissociation constant: 2.51 nM
For compound 3 the middle estimate is 12-fold (1.08 log units) above the measured one, and the stated range ends above it.
By their numbers in this assay, from the lowest: compounds 1 and 3 (each within the scatter of the next); then compound 2.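

In this assay, putting benzyl in place of 4-(1-hydroxyethyl)-2-methoxyphenoxy on a saturated chain carbon, three bonds along the chain from an amine nitrogen in a ring, gives a 4.0-fold lower number from compound 2 to compound 3 (0.60 log units; beyond the scatter) and so marks a modest move toward tighter binding. For the compounds shown here, this is the first comparison in which only one place changes, and it shows that the larger group is not required for tight binding in this pair: benzyl has fewer heavy atoms, no oxygen, and no hydrogen-bond donors or acceptors. No available measurement bears on why the number falls with this change.

The two groups differ in size and in their oxygen atoms at the same time, so this single step cannot separate those two differences. A plain phenoxy group at this place would keep the oxygen link without the methoxy and 1-hydroxyethyl groups, while a cyclohexyl group or a longer chain would test whether an aromatic ring or this chain length matters.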